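The compounds below may be only part of what the source reports. "The series", "measured", "known", "first", "only" and "open" are said of these compounds alone.

Measured so far in a functional assay on MCF7 cells (Homo sapiens) for cytotoxicity, read by MTT assay, with a stated time of 48 h (a lower number here means a stronger inhibitor, a higher number a weaker inhibitor), are two compounds:

- compound 1 `COC(=O)[C@@H]1CCCN1C(=O)C1=C(C)NC(=S)NC1c1cccc(OCCCCOc2cccc(C3NC(=S)NC(C)=C3C(=O)N3CCC[C@H]3C(=O)OC)c2)c1` gives 128 ug/mL
- compound 2 `COC(=O)[C@@H]1CCCN1C(=O)C1=C(C)NC(=S)NC1c1cccc(OC/C=C\COc2cccc(C3NC(=S)NC(C)=C3C(=O)N3CCC[C@H]3C(=O)OC)c2)c1` gives 156 ug/mL

Compound 2 sits within the usual scatter of compound 1, so these two numbers cannot be ranked against each other. Compound 3 `COC(=O)[C@@H]1CCCN1C(=O)C1=C(C)NC(=S)NC1c1cccc(OC/C=C/COc2cccc(C3NC(=S)NC(C)=C3C(=O)N3CCC[C@H]3C(=O)OC)c2)c1` has not yet been measured. It departs from compound 2 as follows: the two compounds have the same atoms and bonds; at least one stereo element is drawn with a configuration in one of them and without one in the other: 1 of 5 stereo elements differ; a double bond is drawn Z in compound 2 and E in compound 3 and nothing else. The atoms and bonds are the same, and a double bond is drawn Z in compound 2 and E in compound 3. Within the data shown here, no measured pair shows what such a change does. With compound 1 at 128 ug/mL and compound 2 at 156 ug/mL lying close together, no shift beyond the scatter is expected in this assay here. The expected step is a 1.1-fold lower number from compound 2 to compound 3 (0.05 log units; within the scatter) and stays inside the scatter. For compound 3 the estimated value is 140 ug/mL with 75 ug/mL to 260 ug/mL as the expected range.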

Compound 3, half-maximal inhibitory concentration: 54 ug/mL
Beside the measured number, compound 3's estimate is 2.6-fold (0.41 log units) above it, and the stated range ends above it.
By their numbers in this assay, from the lowest: compound 3; then compounds 1 and 2 (each within the scatter of the next).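

Compound 1 and compound 2 could not be ranked against each other, so they gave no sign that the chain could change the result in this assay. This result shows that it can: with the same atoms and bonds, turning a Z double bond into an E double bond gives a 2.9-fold lower number from compound 2 to compound 3 (0.46 log units; beyond the scatter), a modest step but one beyond the scatter. The only structural difference to which this step can be tied is stereochemical: the fact that one of compounds 2 and 3 is drawn with a defined configuration and the other without, at the place where they differ

The compounds shown leave open whether the E double bond would have the same effect in a longer chain, or whether a triple bond at that place would fit this trend. They also leave open what a carboxylic acid in place of the methyl ester would do to the number.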